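This account rests on a few compounds, and the source may have more. Where it says the series, first, only, none or still open, it means among the compounds named here.

Compound 1 `O=C1C[C@H]2O[C@H]([C@H](O)c3ccccc3)[C@H](O)[C@H]2O1`: 35200 nM
Compound 2 `CO[C@@H](c1ccccc1)[C@H]1O[C@@H]2CC(=O)O[C@@H]2[C@H]1O`: 5310 nM
Compound 3 `CO[C@@H]1[C@H]2OC(=O)C[C@H]2O[C@@H]1[C@H](O)c1ccccc1`: 23600 nM

All three compounds were tested in a functional assay on A549 cells (Homo sapiens) for inhibition, read by MTT assay, with a stated time of 72 h; a higher number here means a weaker inhibitor, a lower number a stronger inhibitor. Compound 1 gives 35200 nM, compound 3 gives 23600 nM, and compound 2 gives 5310 nM. Compound 3 differs from compound 1 in one place: methyl in place of hydrogen on an oxygen on a saturated carbon. The step this made is a 1.5-fold lower number from compound 1 to compound 3 (0.17 log units; within the scatter), so the two values are not told apart by this assay. Compound 2 and compound 1 differ in more than one place; the difference between the two cores is not broken down here. The gaps from compound 2 to compound 3 and to compound 1 both lie beyond the usual scatter, so compound 2 is the strongest inhibitor of the three in this assay.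

Compound 4 `CO[C@@H]1[C@H]2OC(=O)C[C@H]2O[C@@H]1[C@@H](OC)c1ccccc1` has not yet been measured. It differs from compound 2 in one place: methyl in place of hydrogen on an oxygen on a saturated carbon. This is the same change as from compound 1 to compound 3, at a place described in the same words. The expected step from compound 2 to compound 4 in this assay is a 1.5-fold lower number from compound 2 to compound 4 (0.17 log units; within the scatter), set beside the earlier step of a 1.5-fold lower number from compound 1 to compound 3 (0.17 log units; within the scatter), and it rests on that earlier step alone. Since that step lay within the scatter, compound 4 is expected to land close to compound 2. The estimate for compound 4 in this assay is 3600 nM, expected to fall between 1500 nM and 9000 nM.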

Compound 4, half-maximal inhibitory concentration: 25100 nM
The estimate for compound 4 lay 7.0-fold (0.84 log units) below the measured number, outside the stated range (above it).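

The new step is a 4.7-fold higher number from compound 2 to compound 4 (0.67 log units; beyond the scatter), so in this assay the change from hydroxy to methoxy has a clear effect here, unlike the first time it was seen. Set side by side, the two results show that the size and even the direction of this step did not carry over from one core to the other: the same change on two cores in this assay, a 1.5-fold lower number (0.17 log units; within the scatter) from compound 1 to compound 3 and a 4.7-fold higher number (0.67 log units; beyond the scatter) from compound 2 to compound 4, 7.1-fold (0.85 log units) apart, beyond the scatter of two such steps What holds for these two pairs, then, is that a step measured on one core was a poor guide to the same change on the other, but two pairs cannot show what sets the two steps apart or predict the step on any further core.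

The compounds shown carry only hydrogen or methyl on an oxygen on a saturated carbon, which leaves open what a longer chain such as ethyl or an acetyl group would do there, and whether an amine in place of the hydroxy would follow either step. From the compounds shown here alone, it also remains open whether the gap between the two cores would appear again with such groups, or whether it belongs to the methyl group alone.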